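This account rests on a few compounds, and the source may have more. Where it says the series, first, only, none or still open, it means among the compounds named here.

The series is built on the core of compound 1 `COc1ccc(Oc2ccc([C@H]3S[C@@H](C)C(=O)Nc4c3c(C)nn4-c3ccccc3C)cc2)cc1`, which in an assay on isolated protein for agonist activity at Bile acid receptor (Homo sapiens), read by AlphaScreen, with a stated time of 30 min (on this read-out lower numbers stand for an effect already at smaller amounts and higher numbers for an effect only at larger amounts of compound), gives 2200 nM. Compound 2 `Cc1ccccc1-n1nc(C)c2c1NC(=O)[C@H](C)S[C@@H]2c1ccc(-c2ccc(C(=O)O)cc2)cc1` carries a 4-carboxyphenyl group in place of the methoxyphenoxy substituent of compound 1, and in this assay compound 2 is recorded as "not active" (no number reported), so no number stands for it and its position on the scale cannot be placed. The two compounds differ in more than one place, so only the two readings themselves can be set side by side: a measured value for compound 1 and an absence of measurable effect for compound 2.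

Compound 3 `COC(=O)c1ccc(-c2ccc([C@H]3S[C@@H](C)C(=O)Nc4c3c(C)nn4-c3ccccc3C)cc2)cc1` is the next compound to be tested. It differs from compound 2 by methyl in place of hydrogen on an oxygen next to a carbonyl group. Going by the values given here, no measured step covers this change, so the size and direction of the step from compound 2 to compound 3 can only be expected, not read off. Given that compound 2 is "not active" (no number reported), the expectation is that compound 3 either stays beyond the reach of this assay or returns a weak reading near that of compound 1. Compound 3 is therefore estimated at 3500 nM, within a range from 800 nM to 15000 nM.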

Compound 3, half-maximal effective concentration: "not active" (no number reported)
Compound 3: no number reported; no gap can be computed for the estimate.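

Going by these compounds alone, compound 2 and compound 3 are both recorded as "not active" in this assay with no number for either, so no step from the carboxy group to the methoxycarbonyl group can be read. The compounds shown leave open how far each lies from compound 1 on this scale. Nothing available accounts for these two readings.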